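A methyl for fluoro on the shared core

The source may report more compounds than this note shows. Statements on the series, on what has been measured and on what is new or still open speak of the compounds shown alone.

Compound 1 `CC1CCN(c2c(S(=O)(=O)c3ccc(F)cc3)cnc3ccc(F)cc23)CC1`: 87% in an assay on isolated protein for displacement of a labelled ligand from metabotropic glutamate receptor 5 (Homo sapiens), with a stated time of 60 min, tested at 1 uM; on this read-out lower numbers stand for less inhibition and higher numbers for more inhibition at the one concentration tested (going by the name of the read-out)
Compound 2 `Cc1ccc(S(=O)(=O)c2cnc3ccc(F)cc3c2N2CCC(C)CC2)cc1C`: 92%
Compound 3 `COc1ccc(S(=O)(=O)c2cnc3ccc(F)cc3c2N2CCC(C)CC2)cc1`: 85%

Compound 2 gives the top number of the three, yet a number 5 percentage points higher from compound 1 to compound 2 (within the scatter) and a number 7 percentage points lower from compound 2 to compound 3 (within the scatter) lie within the scatter, as does a number 2 percentage points lower from compound 1 to compound 3 (within the scatter), so the three compounds cannot be told apart in this assay. Compound 4 `Cc1ccc2ncc(S(=O)(=O)c3ccc(C)c(C)c3)c(N3CCC(C)CC3)c2c1` differs from compound 2 by methyl in place of fluoro on an aromatic carbon. Among the compounds with values here, no measured step exchanges fluoro for methyl; the only step that replaces a fluoro on an aromatic carbon is a number 2 percentage points lower from compound 1 to compound 3 (within the scatter), which stayed within the scatter, and the two changes on the sulfonyl sulfur were likewise small. Compound 4 is therefore expected to show no step beyond the scatter, a number 3 percentage points lower from compound 2 to compound 4 (within the scatter). The estimate for compound 4 in this assay is 89%, with a range from 78% to 97%.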

Compound 4, a percentage reported as inhibition, at one concentration (the size of the read-out at that concentration, not a potency): 90%
Estimate against measurement, compound 4: 1 percentage points below, within the range that was stated.
By their numbers in this assay, from the lowest: compounds 3, 1, 4 and 2 (each within the scatter of the next).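

The other compounds shown all carry fluoro at this position of the shared core, so the new step is the only one that speaks to it: in this assay, methyl in place of fluoro gives a number 2 percentage points lower from compound 2 to compound 4 (within the scatter). At the one concentration tested, methyl and fluoro on this aromatic carbon therefore cannot be told apart. Nothing measured here bears on the reason for this. On these data alone, what an amine or a carboxylic acid at this position would do stays open. So does whether methyl and fluoro would separate across a range of concentrations.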